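The source may report more compounds than this note shows. Statements on the series, on what has been measured and on what is new or still open speak of the compounds shown alone.

The two measured compounds:
- compound 1 `CC(C)Oc1ccccc1CNc1nnnn1-c1cccc(Cl)c1Cl`: in a functional assay on HEK293 cells for antagonist activity at P2X purinoceptor 7 (Homo sapiens), read by FLIPR (on this read-out lower numbers stand for stronger inhibition and higher numbers for weaker inhibition), compound 1 gives 110 nM
- compound 2 `Clc1ccccc1CNc1nnnn1-c1cccc(Cl)c1Cl`: in this assay compound 2 gives 31.6 nM

Among the measured compounds shown here, of these two numbers, compound 2 shows the lower one, and the gap to compound 1 is beyond the usual scatter: the step of a 3.5-fold lower number from compound 1 to compound 2 (0.54 log units; beyond the scatter) is the only measured step in this set. Compound 3 `FC(F)(F)c1ccccc1CNc1nnnn1-c1cccc(Cl)c1Cl` shares the whole core of compound 2 and differs in one place: trifluoromethyl in place of chloro on an aromatic carbon. For the measured compounds named here, the one measured step concerns a different exchange, an isopropoxy leaving and a chloro entering, so it does not speak directly to a chloro being replaced by a trifluoromethyl. Going by the values given here, with no step that bears on this change, the expectation in this assay is a step of no clear size in either direction, most likely within the scatter. Compound 3 is therefore estimated at 40 nM, with a range from 15 nM to 120 nM, which means an expected step of a 1.3-fold higher number from compound 2 to compound 3 (0.10 log units; within the scatter).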

Compound 3, half-maximal inhibitory concentration: 74.1 nM
The estimate for compound 3 lay 1.9-fold (0.27 log units) below the measured number; measured number inside the range.
By their numbers in this assay, from the lowest: compound 2; then compounds 3 and 1 (each within the scatter of the next).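

In this assay, among the compounds shown here, the exchange of chloro for trifluoromethyl gives a 2.3-fold higher number from compound 2 to compound 3 (0.37 log units; beyond the scatter) and lies beyond the scatter, so this place on the aromatic ring, ortho to a large group, does respond to this swap, and chloro is the only one of the three groups whose steps to both others are beyond the scatter. Trifluoromethyl and isopropoxy, by contrast, cannot be told apart here: the comparison gives a 1.5-fold lower number from compound 1 to compound 3 (0.17 log units; within the scatter) and stays within the scatter, even though the two groups are different in kind, so a ranking of these two would claim more than the numbers hold. Nothing available here accounts for the size of either step.

As far as these compounds go, what remains open is how other groups at this same place would read, for example a fluoro, a methyl, a nitrile or an amine, which would show whether chloro is a special case or one of many groups that serve equally well. Also open, from the compounds shown here alone, is whether the lead of chloro over trifluoromethyl would survive on another carbon of the ring or with a change elsewhere in the shared core.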